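A few compounds are considered here, and "the series" means these few. Any claim that something is new, unique, unknown or untested is made for them only; others in the source may bear on it.

Measured so far:
Compound 1 `Cc1nc2cc(OC[C@H](O)CN3CCN(Cc4noc(-c5ccc(C(F)(F)F)cc5)n4)CC3)ccc2s1` — 380 nM in a functional assay on mitochondria from heart for inhibition of peroxisomal acyl-coenzyme A oxidase 1 (Rattus norvegicus); on this read-out lower numbers stand for stronger inhibition and higher numbers for weaker inhibition
Compound 2 `Cc1nc2cc(OC[C@H](O)CN3CCN(Cc4csc(-c5ccc(C(F)(F)F)cc5)n4)CC3)ccc2s1` — 1300 nM in this assay

Of these two numbers, compound 1 stands lowest; compound 2 sits beyond the scatter above it, so on this read-out compound 1 is the stronger inhibitor of the pair. Compound 3 `Cc1nc2cc(OC[C@H](O)CN3CCN(Cc4noc(-c5cccc(Cl)c5)n4)CC3)ccc2s1` has not yet been measured. It differs from compound 1 in one place: 3-chlorophenyl in place of 4-(trifluoromethyl)phenyl on an aromatic carbon. Going by the values given here, no pair of measured compounds differs in that same place, so there is no measured step to lean on for this change, and what follows is an expectation only. Among the compounds with values here, a step of moderate size toward a higher number is expected, with a real chance of no step beyond the scatter, because the only firm anchor is compound 1 at 380 nM. Compound 3 is estimated at 800 nM, within the range 250 nM to 2500 nM, which would mean a step of a 2.1-fold higher number from compound 1 to compound 3 (0.32 log units; beyond the scatter).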

Compound 3, half-maximal inhibitory concentration: 4120 nM
Compound 3: middle estimate off by 5.2-fold (0.71 log units), on the low side, outside the stated range (above it).
By their numbers in this assay, from the lowest: compound 1; then compound 2; then compound 3.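

In this assay, going by these compounds alone, placing 3-chlorophenyl in place of 4-(trifluoromethyl)phenyl on the five-membered aromatic ring gives an 11-fold higher number from compound 1 to compound 3 (1.04 log units; beyond the scatter), a large loss of inhibition and the first measured step at this position. The aryl group here is therefore not freely interchangeable, although the two groups have the same kind of ring and neither has any hydrogen-bond donors or acceptors. The swap changes both the substituent and its place on the phenyl ring, and no available measurement explains the step.

Which of those two changes matters more remains open, and 4-chlorophenyl and 3-(trifluoromethyl)phenyl would separate them by altering one at a time. On these data alone, whether plain phenyl, or a ring carrying an amine or a carboxylic acid, is tolerated at this position also remains unknown.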